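Benzyl-ether stilbenes: amine-methyl groups in place of formyl

The source may hold more compounds than are shown below. What is called first, only, known or untested is meant among the compounds shown, and "the series" means these compounds.

Measured so far:
compound 1 `COc1ccc(/C=C\c2cc(OC)c(OC)c(OC)c2)cc1OCc1ccc(C=O)cc1` — 4800 nM
compound 2 `COc1ccc(/C=C\c2cc(OC)c(OC)c(OC)c2)cc1OCc1ccc(CN2CC(C(=O)O)C2)cc1` — 6500 nM

In a functional assay on HeLa cells (Homo sapiens) for antiproliferative activity, read by CCK-8 assay, with a stated time of 48 h (on this read-out lower numbers stand for stronger inhibition and higher numbers for weaker inhibition), compound 1 gives 4800 nM, the lowest of the two numbers shown; its nearest neighbour is compound 2 with 6500 nM, and the step of a 1.4-fold higher number from compound 1 to compound 2 (0.13 log units; within the scatter) is within the scatter, so no order between the two can be claimed. Compound 3 `COc1ccc(/C=C\c2cc(OC)c(OC)c(OC)c2)cc1OCc1ccc(CN2CC[C@@H](O)C2)cc1` has not yet been measured. It differs from compound 1 as follows: (3-hydroxypyrrolidin-1-yl)methyl in place of formyl on an aromatic carbon. Among the compounds with values here, the only measured step that bears on this change is a 1.4-fold higher number from compound 1 to compound 2 (0.13 log units; within the scatter), where (3-carboxyazetidin-1-yl)methyl replaced the same formyl on the same aromatic carbon and the number stayed within the scatter. Two compounds are too few for a pattern, but nothing in them points to a step beyond the scatter in this assay for the new change. Compound 3 is therefore expected to give 5500 nM in this assay, with a range from 2500 nM to 12000 nM. That estimate means an expected step of a 1.1-fold higher number from compound 1 to compound 3 (0.06 log units; within the scatter), within the scatter.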

Compound 3, half-maximal inhibitory concentration: > 10000 nM
Compound 3: no number, only a limit; the forecaster's own chance of this, stated with the estimate: 5%; at least 1.8-fold (0.25 log units) between middle value and limit.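

In this assay compound 3 gives only a limit, not a number: the limit of > 10000 nM in this assay, at which 1 of the 3 values shown sits.

Even so, the data now hold a change at this aromatic carbon that reaches beyond the scatter: with (3-hydroxypyrrolidin-1-yl)methyl in place of formyl, the step is an at least 2.0-fold higher number from compound 1 to compound 3 (0.31 log units; beyond the scatter). So the earlier result with (3-carboxyazetidin-1-yl)methyl does not extend to every amine-methyl group in place of formyl. The step of an at least 1.5-fold higher number from compound 2 to compound 3 (0.18 log units; that floor lies within the scatter) has a floor within the scatter, so the limit does not put the two amine-methyl groups in order.

From the compounds shown here alone, how far the true value of compound 3 lies past its limit remains open. Also open, going by these compounds, is whether a plain pyrrolidine without the hydroxyl, an open-chain dimethylamine or a longer chain to the amine at this carbon would follow compound 2 or compound 3.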